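The compounds below may be only part of what the source reports. "The series", "measured", "known", "first", "only" and "open" are said of these compounds alone.

Three compounds of the shared core have been examined in an ADME assay on cells for inhibition of Amine oxidase [flavin-containing] A (Homo sapiens), read by spectrophotometry; a lower number here means a stronger inhibitor, a higher number a weaker inhibitor. Compound 1 `Oc1ccc(NC(=S)Nc2ccc3[nH]ccc3c2)cc1` is reported in this assay as "not active" (no number reported). Compound 2 `O=C(c1ccccc1)c1ccc(NC(=S)Nc2ccc3[nH]ccc3c2)cc1` is likewise reported in this assay as "not active" (no number reported). Compound 3 `Oc1ccc(NC(=S)Nc2ccc3[nH]ccc3c2)cc1Cl` gives in this assay a half-maximal inhibitory concentration of 58000 nM, the only entry in the set that comes with a number; compound 3 therefore stands alone among the numbers shown, the other two entries carrying no number at all. Within the data shown here, nothing can be said of the size of a step between measured compounds, since no measured pair differs in one place.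

Compound 4 `COC(=O)c1cc(NC(=S)Nc2ccc3[nH]ccc3c2)ccc1O` has not yet been measured. It differs from compound 3 in one place: methoxycarbonyl in place of chloro on an aromatic carbon. Among the measured compounds shown here, no measured pair offers a comparable change, so neither direction nor size of the step from compound 3 to compound 4 can be read from the data; the weak inhibition of compound 3 is the only anchor. The estimated step of a 1.0-fold higher number from compound 3 to compound 4 (0.01 log units; within the scatter) is expected to be none beyond the scatter. For compound 4 a half-maximal inhibitory concentration of 60000 nM is expected, within 20000 nM to 200000 nM, with a real chance that this assay again reports no number.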

Compound 4, half-maximal inhibitory concentration: "not active" (no number reported)
No number was reported for compound 4; no gap can be computed for the estimate.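

In this assay, among these compounds, compound 4 gives "not active" (no number reported), so no step from compound 3 to compound 4 can be read. No measurement at hand bears on this result. The compounds shown leave open how far methoxycarbonyl in place of chloro shifts inhibition, and whether any change to the shared core yields a stronger inhibitor than compound 3.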